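Swapping Bromo for Chloro on a Sulfonamide-Bearing Core

The compounds below may be only part of what the source reports. "The series", "measured", "known", "first", "only" and "open" are said of these compounds alone.

Compound 2 `NS(=O)(=O)c1cccc(/N=C2\NC(=O)/C(=C3/C(=O)Nc4ccc(Br)cc43)S2)c1` was tested in a functional assay on MCF7 cells (Homo sapiens) for antiproliferative activity, read by MTT assay; on this read-out lower numbers stand for stronger inhibition and higher numbers for weaker inhibition. In this assay compound 2 gives only a limit, > 200000 nM, and no number. That position is the limit of > 200000 nM in this assay, at which 2 of the 3 values shown sit. Compound 1 `NS(=O)(=O)c1ccc(/N=C2\NC(=O)/C(=C3/C(=O)Nc4ccc(Br)cc43)S2)cc1`, carrying its sulfonamide on another carbon, gives 11300 nM in this assay. Compound 3 `NS(=O)(=O)c1ccc(/N=C2\NC(=O)/C(=C3/C(=O)Nc4ccc([N+](=O)[O-])cc43)S2)cc1` also gives only a limit in this assay, > 200000 nM. Among the measured compounds shown here, the single one-point step among the measured compounds is an at least 17-fold higher number from compound 1 to compound 3 (1.24 log units; beyond the scatter). For the measured compounds named here, that step concerns a nitro group and says nothing about chlorine, so no measured step bears directly on the change examined here.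

Compound 4 `NS(=O)(=O)c1cccc(/N=C2\NC(=O)/C(=C3/C(=O)Nc4ccc(Cl)cc43)S2)c1` differs from compound 2 by chloro in place of bromo on an aromatic carbon. Going by the values given here, with compound 2 sitting at a limit, and no measured step touching this exchange, the expected step from compound 2 to compound 4 is a number no higher from compound 2 to compound 4 (the limit leaves the size open), a value most likely again at or near the limit. The estimate for compound 4 in this assay is 200000 nM, with an expected range from 40000 nM to 1000000 nM.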

Compound 4, half-maximal inhibitory concentration: > 200000 nM
Compound 4: a limit, no number (the forecaster's own chance of this, stated with the estimate: 70%); the middle value lies on the limit itself.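

Compound 2 and compound 4 both give only a limit in this assay, so the exchange of bromo for chloro yields no readable step: the limit of > 200000 nM in this assay, at which 3 of the 4 values shown sit. The compounds shown leave open how chloro compares with bromo on the core of compound 1, the only compound here with an actual number.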